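Sulfamate series: fluorophenyl to pyridyl swap on the amine

This account rests on a few compounds, and the source may have more. Where it says the series, first, only, none or still open, it means among the compounds named here.

Two members of the sulfamate series have been run in an assay on HEK293 cells for inhibition of Steryl-sulfatase (Homo sapiens), tested at 0.1 uM; on this read-out higher numbers stand for a stronger effect at the one concentration tested and lower numbers for a weaker effect. Compound 1 `NS(=O)(=O)Oc1ccc2c(c1)CN(C(=O)c1ccc(N(Cc3ccccc3)Cc3ccco3)cc1)CC2` gives 90.8%. Compound 2 `CCN(Cc1ccc(F)cc1)c1cccc(C(=O)N2CCc3ccc(OS(N)(=O)=O)cc3C2)c1` gives 10.9%, the lowest of the two numbers; compound 1 lies a large stretch above it, beyond the scatter. Compound 3 `CCN(Cc1cccnc1)c1cccc(C(=O)N2CCc3ccc(OS(N)(=O)=O)cc3C2)c1` is not yet measured. It differs from compound 2 in one place: pyridin-3-yl in place of 4-fluorophenyl on a saturated chain carbon bound to a nitrogen on an aromatic ring. Going by the values given here, no measured pair shows this change, so no step size is known for it. The expectation is a step from compound 2 to compound 3 of a number 1.1 percentage points higher from compound 2 to compound 3 (within the scatter), within the scatter in either direction. Compound 3 is expected to give 12%, with a range of 0% to 35%.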

Compound 3, a percentage reported as inhibition, at one concentration (the size of the read-out at that concentration, not a potency): 14.3%
Compound 3: the middle estimate sits 2.3 percentage points below what was measured; low and high end bracket the measured number.
By their numbers in this assay, from the lowest: compounds 2 and 3 (each within the scatter of the next); then compound 1.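

Within this assay the swap to pyridin-3-yl from 4-fluorophenyl, on a saturated chain carbon bound to a nitrogen on an aromatic ring, gives a number 3.4 percentage points higher from compound 2 to compound 3 (within the scatter) and so moves the read-out no further than the scatter. At this position, then, a ring nitrogen with one hydrogen-bond acceptor can replace the fluorine-bearing carbon ring without a readable change at the one concentration tested. Nothing available here bears on why this step is so small.

On these data alone, whether this position responds to any group remains open. A carboxylic acid or a morpholine on the same chain carbon would test that.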